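A Nitrate Ester Gives Way to a Bromoethyl Group

This account rests on a few compounds, and the source may have more. Where it says the series, first, only, none or still open, it means among the compounds named here.

Compound 1, `O=C(CO[N+](=O)[O-])Nc1ccc(C(=O)/C=C/c2ccc(Cl)cc2)cc1`, gives 67% in a functional assay on the whole organism (strain albino) for inhibition, with Rattus norvegicus as the target, read by paw edema, with stated times of 30 min and 4 h, at a dose of 100 mg/kg by the oral route; a lower number here means less inhibition, a higher number more inhibition at the dose given (going by the name of the read-out).
Compound 2, `COc1ccc(/C=C/C(=O)c2ccc(NC(=O)CO[N+](=O)[O-])cc2)cc1`, gives 51% in this assay.

Of the compounds shown here, two have been measured in this assay. Among the compounds with values here, compound 2 stands lowest of the two numbers; the one measured step, a number 16 percentage points lower from compound 1 to compound 2 (beyond the scatter), was a modest drop beyond the scatter, and it concerns a change on an aromatic carbon, not the amide side chain.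

Compound 3, `COc1ccc(/C=C/C(=O)c2ccc(NC(=O)C(C)Br)cc2)cc1`, differs from compound 2 in one place:

1-bromoethyl in place of (nitrooxy)methyl on a carbonyl carbon

Within the data shown here, no measured step touches this part of the molecule. The step of a number 16 percentage points lower from compound 1 to compound 2 (beyond the scatter) does not bear on an exchange at the carbonyl carbon, so the data give no direction for compound 3. In the absence of any guiding step, compound 3 is expected to give a number close to that of compound 2, with a wide range. The estimate for compound 3 in this assay is 50%, between 30% and 70%. The expected step is therefore a number 1 percentage points lower from compound 2 to compound 3 (within the scatter), a change that is not expected to exceed the scatter.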

Compound 3, a percentage reported as inhibition, in the whole organism at one dose (the size of the read-out at that dose, not a potency): 38%
The estimate for compound 3 lay 12 percentage points above the measured number; the measured number falls inside the stated range.
By their numbers in this assay, from the lowest: compound 3; then compound 2; then compound 1.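

Within the data shown here, the exchange of (nitrooxy)methyl for 1-bromoethyl on the carbonyl carbon gives the first reading of this side of the molecule, and in this assay it is a number 13 percentage points lower from compound 2 to compound 3 (beyond the scatter), so the group at this position does affect the number. The nitrate ester is also not needed for a measurable reading at this dose, since compound 3, which carries no nitrooxy group, still gives 38% in the same test. Nothing measured here explains the drop, or separates the loss of the (nitrooxy)methyl from the arrival of the 1-bromoethyl.

Going by these compounds, it remains open what a plain methyl, an aminomethyl group or a carboxylic acid would give on the same carbonyl carbon, and so whether the bromine or the carbon chain of the 1-bromoethyl matters for the reading. On these data alone, it is also open whether the same exchange would give a step of similar direction and size on compound 1, which has chloro in place of methoxy, so the step cannot yet be taken beyond this one pair.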